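A few compounds are considered here, and "the series" means these few. Any claim that something is new, unique, unknown or untested is made for them only; others in the source may bear on it.

Measured so far in an ADME assay on Vero cells (Chlorocebus sabaeus) for cytotoxicity, read by neutral red uptake, with a stated time of 48 h; a lower number here means a stronger inhibitor, a higher number a weaker inhibitor:
- Compound 1 `CN(C)c1nc(Cl)nc2c1ncn2CCNc1ccnc2cc(Cl)ccc12`: > 11800 nM, a limit
- Compound 2 `CCN(CC)c1nc(Cl)nc2c1ncn2CCNc1ccnc2cc(Cl)ccc12`: > 11000 nM, a limit
- Compound 3 `Clc1ccc2c(NCCCn3cnc4c(N5CCCC5)nc(Cl)nc43)ccnc2c1`: > 10700 nM, a limit

Compound 3 has no number of its own in this assay, only the limit > 10700 nM. The two other values beside it are limits as well, so it cannot be placed in order against them.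

Compound 4 `CN1CCN(c2nc(Cl)nc3c2ncn3CCCNc2ccnc3cc(Cl)ccc23)CC1` keeps the core of compound 3 and changes one group, with 4-methylpiperazin-1-yl in place of pyrrolidin-1-yl on an aromatic carbon.

Within the data shown here, only one measured step comes near this change, diethylamino in place of dimethylamino, also on an aromatic carbon: a step that the two limits leave unreadable from compound 1 to compound 2. It offers no size to carry over, and it gives no direction either.

The expectation therefore rests on the limit of compound 3 at > 10700 nM, and no step beyond the usual scatter is expected in either direction. The estimated change is a step that the limit leaves unreadable from compound 3 to compound 4, which is expected to be a weak figure, since compound 4 may well report only a limit too. For compound 4 the expected value is 11000 nM. The estimated range for compound 4 runs from 4000 nM to 25000 nM.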

Compound 4, half-maximal inhibitory concentration: > 10100 nM
Compound 4: a limit, no number; the forecaster's own chance of this, stated with the estimate: 75%; the middle value does not contradict the limit.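

In this assay compound 4 gives only a limit, > 10100 nM. Compound 3 is also held to a limit, so no step can be read between compound 3 and compound 4. The compounds shown leave open what the actual half-maximal inhibitory concentration of any of the four is in this assay, and whether changing the amino group shifts it at all.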